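The compounds below may be only part of what the source reports. "The series", "measured", "known", "first", "only" and "open" are said of these compounds alone.

Compound 1 `CC(=O)NCCN(C)c1cccc(OCCCCN)c1` and compound 2 `CC(=O)NCCN(C)c1cccc(OCCCCCCN)c1` share one core and differ only in the length of the chain that carries the terminal amino group. In a functional assay on cells for agonist activity at melatonin receptor type 1A (Homo sapiens), read by GTPgammaS binding, with a stated time of 30 min (on this read-out lower numbers stand for smaller maximal responses and higher numbers for larger maximal responses), compound 1 gives 0.32, and compound 2 gives 0.34. Going by the values given here, the one measured step, a number 0.020 higher from compound 1 to compound 2 (within the scatter), lies within the scatter, so compound 2 stands highest of the two numbers only nominally, with compound 1 a number within the scatter below it.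

Compound 3 `CC(=O)NCCN(C)c1cccc(OCCCCOc2cccc(O)c2)c1` arises from compound 2 through the change (3-hydroxyphenoxy in place of 2-aminoethyl on a saturated chain carbon, four bonds along the chain from an oxygen on an aromatic ring). Among the compounds with values here, no measured step bears on this change: the only step known, a number 0.020 higher from compound 1 to compound 2 (within the scatter), concerns chain length and not the exchange of the amino end for an aromatic group. The expectation for compound 3 therefore rests on compound 2 alone, and a step a number 0.060 higher from compound 2 to compound 3 (within the scatter) of uncertain direction is expected. Compound 3 is estimated at 0.4, within a range from 0.15 to 0.8.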

Compound 3, intrinsic activity: the largest response reached, as a fraction of the reference agonist's: 0.27
Estimate against measurement, compound 3: 0.13 above, and the stated range covers the measured number.
By their numbers in this assay, from the lowest: compounds 3, 1 and 2 (each within the scatter of the next).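

Placing 3-hydroxyphenoxy on a saturated chain carbon, four bonds along the chain from an oxygen on an aromatic ring, gives a number 0.070 lower from compound 2 to compound 3 (within the scatter) in this assay and, set against the amino end of the other compound, a number 0.050 lower from compound 1 to compound 3 (within the scatter) as well. The earlier compounds shown here carried only amino-ended chains, whereas these steps show that an end with a six-membered aromatic ring also stays within the scatter of both at this place. No available evidence bears on this result.

As far as these compounds go, whether an unsubstituted phenoxy, a methoxyphenoxy or a carboxylic acid at this place would give a step beyond the scatter remains open. Also open, from the compounds shown here alone, is what a longer chain carrying the 3-hydroxyphenoxy end would give on this read-out.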